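Amide Nitrogen Substituent Change on a Shared Core

The source may report more compounds than this note shows. Statements on the series, on what has been measured and on what is new or still open speak of the compounds shown alone.

compound 1 `COc1cccc2cc(C(=O)NC3CCCC3)c(=N)oc12`: 20%
compound 2 `COc1cccc2cc(C(=O)NC(CO)(CO)CO)c(=N)oc12`: 18%

In an assay on HeLa cells for displacement of a labelled ligand from adenosine receptor A3 (Homo sapiens), read by scintillation counting, with a stated time of 180 min, tested at 10 uM (a higher number here means more inhibition at the concentration tested (going by the name of the read-out), a lower number less inhibition), compound 2 and compound 1 cannot be told apart, since the step of a number 2 percentage points lower from compound 1 to compound 2 (within the scatter) is within the scatter. Compound 3 `COc1cccc2cc(C(=O)NCCCCCO)c(=N)oc12` differs from compound 2 by 5-hydroxypentyl in place of 2-hydroxy-1,1-bis(hydroxymethyl)ethyl on an amide-type nitrogen. Within the data shown here, the one measured step that bears on this, a number 2 percentage points lower from compound 1 to compound 2 (within the scatter), also exchanged the group on the amide-type nitrogen and stayed within the scatter, so compound 3 is expected to show no step beyond the scatter, a number 2 percentage points higher from compound 2 to compound 3 (within the scatter). Compound 3 is therefore estimated at 20%, with a range from 5% to 35%.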

Compound 3, a percentage reported as inhibition, at one concentration (the size of the read-out at that concentration, not a potency): 13%
Compound 3: the middle estimate sits 7 percentage points above what was measured; the range from low to high includes it.
By their numbers in this assay, from the lowest: compounds 3, 2 and 1 (each within the scatter of the next).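

In this assay, 5-hydroxypentyl in place of 2-hydroxy-1,1-bis(hydroxymethyl)ethyl on the amide-type nitrogen gives a number 5 percentage points lower from compound 2 to compound 3 (within the scatter), and 5-hydroxypentyl in place of cyclopentyl gives a number 7 percentage points lower from compound 1 to compound 3 (within the scatter). An unbranched chain without a ring thus joins the branched group and the cyclopentyl ring as a third substituent on this nitrogen that cannot be told apart from the others. No evidence is available to interpret these small differences. From the compounds shown here alone, whether an amine, a carboxylic acid or a longer chain on this nitrogen would produce a step beyond the scatter remains open.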